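Aryl Swap on a Triazole in a Spiro Series

The source may report more compounds than this note shows. Statements on the series, on what has been measured and on what is new or still open speak of the compounds shown alone.

Measured compounds:
Compound 1, `Cc1ccc(Cl)cc1-n1nncc1CN1C(=O)C2(C(C#N)=C(N)Oc3c2c2nc4ccccc4nc2c2ccccc32)c2ccccc21`, in a functional assay on MCF7 cells (Homo sapiens) for antiproliferative activity, read by MTT assay, with a stated time of 48 h; a lower number here means a stronger inhibitor, a higher number a weaker inhibitor: > 50000 nM
Compound 2, `N#CC1=C(N)Oc2c(N)cc3nc4ccccc4nc3c2C12C(=O)N(Cc1cnnn1-c1ccc(Cl)cc1)c1ccccc12`, in this assay: > 50000 nM

Compound 1 gives only a limit of this assay and not a number. Compound 2 likewise gives only a limit of this assay and not a number. Compound 2 therefore stands at the same limit as every value shown (the limit of > 50000 nM in this assay, at which 2 of the 2 values shown sit), and nothing places it above or below compound 1.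

Compound 3, `COc1ccc(OC)c(-n2nncc2CN2C(=O)C3(C(C#N)=C(N)Oc4c(N)cc5nc6ccccc6nc5c43)c3ccccc32)c1`, has not yet been measured. It differs from compound 2 in one place: 2,5-dimethoxyphenyl in place of 4-chlorophenyl on an aromatic nitrogen. Among the compounds with values here, no step between two measured compounds is available to set the size of such a change in this assay, and the two values shown, both limits, reveal nothing about the direction in which an exchange on that aromatic nitrogen leads. The step from compound 2 to compound 3 is therefore expected to stay within the scatter, most likely with compound 3 again at the limit. The expected step is a step that the limit leaves unreadable from compound 2 to compound 3. For compound 3 the estimate in this assay is 60000 nM, with a range from 20000 nM to 200000 nM.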

Compound 3, half-maximal inhibitory concentration: 28100 nM
Beside the measured number, compound 3's estimate is 2.1-fold (0.33 log units) above it; low and high end bracket the measured number.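

Among the compounds shown, only compound 3 gives a number rather than a limit in this assay, which shows that a change at this aromatic nitrogen of the five-membered aromatic ring with 3 nitrogen can bring a compound into the readable range of the assay. The exchange of 4-chlorophenyl for 2,5-dimethoxyphenyl gives an at least 1.7-fold lower number from compound 2 to compound 3 (0.25 log units; that floor lies within the scatter), so the floor of this step does not establish a difference beyond the usual scatter, although the true step may be larger. Its full size cannot be read because compound 2 gives only a limit: the limit of > 50000 nM in this assay, at which 2 of the 3 values shown sit.

The change removes a chlorine and adds two methoxy groups in a single exchange, and 2 hydrogen-bond acceptors enter where the leaving group has 0, so the compounds shown do not separate the part played by each of these differences. Also open, as far as these compounds go, is how a plain phenyl ring, a hydroxyl group or an amine on the aryl ring at this nitrogen would read in this assay, and whether any aryl group here can give a much lower number.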